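This account rests on a few compounds, and the source may have more. Where it says the series, first, only, none or still open, it means among the compounds named here.

Of the compounds shown here, three built on a shared core have been tested in a functional assay on HL-60 cells (Homo sapiens) for antiproliferative activity, read by MTT assay, with a stated time of 72 h; a lower number here means a stronger inhibitor, a higher number a weaker inhibitor. Compound 1 `COc1ccccc1-c1ncnn1-c1cc(OC)c(OC)c(OC)c1` carries a 2-methoxyphenyl on that core. In this assay compound 1 gives > 10000 nM, which is a limit of the assay and not a number. Compound 2 `COc1cc(-c2ncnn2-c2cccc(N)c2)cc(OC)c1OC` gives > 10000 nM, again a limit. Compound 3 `COc1cc(-c2ncnn2-c2ccccc2)cc(OC)c1OC` gives > 10000 nM, also a limit. The one step among these that changes a single place, a step that the two limits leave unreadable from compound 2 to compound 3, cannot be read in size because of the limit of > 10000 nM in this assay, at which 3 of the 3 values shown sit. Compound 1 thus stands at the same limit as the other two, and no number places it above or below them.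

Compound 4 `COc1cccc(-c2ncnn2-c2cc(OC)c(OC)c(OC)c2)c1` differs from compound 1 in one place: 3-methoxyphenyl in place of 2-methoxyphenyl on an aromatic carbon. No measured step changes this group, so nothing shown speaks directly to this change. Within the data shown here, every value so far sits at the limit, and the only measured step runs between two limits. Compound 4 is therefore expected to remain at the limit as well. The step that the limit leaves unreadable from compound 1 to compound 4 is estimated to fall within the usual scatter. The estimate for compound 4 is 20000 nM, with a range from 5000 nM to 100000 nM.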

Compound 4, half-maximal inhibitory concentration: > 10000 nM
Compound 4 gave a limit, no number; the forecaster's own chance of this, stated with the estimate: 85%; the middle value is on the limit's open side.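

In this assay compound 4 gives > 10000 nM, which is a limit of the assay and not a number. Among these compounds, the change from compound 1 to compound 4 therefore gives no step that can be read: the limit of > 10000 nM in this assay, at which 4 of the 4 values shown sit. The compounds shown leave open which group on the shared core, if any, would give a real number in this assay.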